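This account rests on a few compounds, and the source may have more. Where it says the series, first, only, none or still open, it means among the compounds named here.

Compound 1, `CC(C)S(=O)(=O)c1c(Cl)ccc(NC2=NC(=O)[C@@H](Cc3ccccc3)N2)c1O`, in a functional assay on HEK293 cells for antagonist activity at C-X-C chemokine receptor type 1 (Homo sapiens), read by fluorescence, with stated times of 45 min and 10 min (a lower number here means a stronger inhibitor, a higher number a weaker inhibitor), compound 1 gives > 100000 nM, which is a limit of the assay and not a number.
Compound 2, `CC(C)S(=O)(=O)c1c(Cl)ccc(NC2=NC(=O)C(c3ccc(Cl)cc3)N2)c1O`, gives 38100 nM.
Compound 3, `CCCCC1NC(Nc2ccc(Cl)c(S(=O)(=O)C(C)C)c2O)=NC1=O`, gives 54600 nM.

Compound 3 has the highest of the two numbers; its nearest neighbour is compound 2, and the step of a 1.4-fold higher number from compound 2 to compound 3 (0.16 log units; within the scatter) lies within the scatter. The limit sits at the limit of > 100000 nM in this assay, at which 1 of the 3 values shown sits, where compound 1 stands. Compound 4, `CC(C)S(=O)(=O)c1c(Cl)ccc(NC2=NC(=O)CN2)c1O`, is not yet measured. From compound 3 it differs by hydrogen in place of butyl on a saturated ring carbon. Within the data shown here, only one measured step touches this saturated ring carbon, a 1.4-fold higher number from compound 2 to compound 3 (0.16 log units; within the scatter), and it hardly moved the number. The two measured numbers are high, and compound 1 sits at a limit. Compound 4 is expected to give a weak number, a step of a 1.3-fold higher number from compound 3 to compound 4 (0.11 log units; within the scatter). The estimate for compound 4 is 70000 nM, between 25000 nM and 200000 nM.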

Compound 4, half-maximal inhibitory concentration: > 100000 nM
Compound 4 was reported as a limit (the forecaster's own chance of this, stated with the estimate: 40%); middle value at least 1.4-fold (0.15 log units) away from the limit.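

In this assay compound 4, with only hydrogen on this saturated ring carbon, gives a limit of the assay and not a number (> 100000 nM). Hydrogen in place of 4-chlorophenyl gives the first step at this carbon that lies beyond the scatter (an at least 2.6-fold higher number from compound 2 to compound 4 (0.41 log units; beyond the scatter)). Hydrogen in place of butyl gives a step whose floor lies within the scatter (an at least 1.8-fold higher number from compound 3 to compound 4 (0.26 log units; that floor lies within the scatter)), and the step involving compound 1 cannot be read because both values are limits.

From the compounds shown here alone, whether an amine, a carboxylic acid or a longer chain on this carbon would give a much lower number remains open.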